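Side chain change in a two-compound series

This account rests on a few compounds, and the source may have more. Where it says the series, first, only, none or still open, it means among the compounds named here.

Compound 1 `CC1(C)CC(=O)Nc2ccc(Cl)cc21` and compound 2 `CCCNC1=Nc2ccc(Cl)cc2C(C)(C)C1` share one core. In a functional assay on MDA-MB-231 cells (Homo sapiens) for cytotoxicity, read by MTT assay, with a stated time of 72 h, tested at 1 uM, in the absence of a further agent (a lower number here means a stronger effect, a higher number a weaker effect of the compound at the concentration tested), compound 1 gives 82.3%; in this assay compound 2 gives 90.7%, the higher of the two numbers, though its gap to compound 1 lies within the scatter. Compound 3 `CN(C)CCNC1=Nc2ccc(Cl)cc2C(C)(C)C1` carries, relative to compound 2, (dimethylamino in place of methyl on a saturated chain carbon, two bonds along the chain from an amine nitrogen). Among the measured compounds shown here, no step between measured compounds speaks to this change, so nothing suggests a move beyond the scatter in this assay in either direction. For compound 3 the expected step is a number 4.7 percentage points lower from compound 2 to compound 3 (within the scatter). Compound 3 is expected to give 86% in this assay, within 66% to 100%.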

Compound 3, a percentage reported as activity, at one concentration (the size of the read-out at that concentration, not a potency): 66.9%
Compound 3: the middle estimate sits 19.1 percentage points above what was measured; low and high end bracket the measured number.
By their numbers in this assay, from the lowest: compound 3; then compounds 1 and 2 (each within the scatter of the next).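

Among the compounds shown here, the side chain on the amine nitrogen is a place where this read-out can move: in this assay the change from methyl to dimethylamino at this chain carbon gives a number 23.8 percentage points lower from compound 2 to compound 3 (beyond the scatter) and is the first step to pass the scatter. The lower number marks a stronger effect at the tested concentration, though no potency can be read from it. Nothing available bears on the origin of this step.

Going by these compounds, it remains open whether a morpholine or a pyrrolidine would serve in place of dimethylamino. Also open, on these data alone, is how a longer chain carrying the same dimethylamino group, or a carboxylic acid at the chain end, would read.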